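A few compounds are considered here, and "the series" means these few. Any claim that something is new, unique, unknown or untested is made for them only; others in the source may bear on it.

Three measured compounds set the stage. Compound 1 `O=C(NCc1ccc(S(=O)(=O)N2CCCCC2)cc1)c1cc2cnccc2s1` gives 15% in an ADME assay on microsomes from liver (Homo sapiens) for metabolic stability, read by LC-MS, with a stated time of 30 min, tested at 1 uM; a higher number here means that more of the compound is left, a lower number that less of the compound is left. Compound 2 `O=C(NCc1ccc(S(=O)(=O)c2ccccc2C(F)(F)F)cc1)c1cc2cnccc2[nH]1` gives 52% in this assay, and compound 3 `O=C(NCc1ccc(S(=O)(=O)c2ccccc2)cc1)c1ccc2nncn2c1` gives 96%. Compound 3 stands highest of the three: its nearest neighbour, compound 2, lies lower by a gap beyond the scatter, and compound 1 lies furthest below it, also beyond the scatter. Within the data shown here, these compounds differ from one another in more than one place, so no single step between measured compounds can be read off.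

The piece now follows the step from compound 3 to compound 4 `O=C(NCc1ccc(S(=O)(=O)c2ccccc2)cc1)c1nc2ccncc2s1`. The change between them is confined to the carbonyl carbon whose other neighbours are an amide-type nitrogen: a group of 9 heavy atoms (6 carbon, 2 nitrogen, 1 sulfur; one five-membered aromatic ring with 2 hetero atoms, one six-membered aromatic ring with 1 hetero atom) in place of a group of 9 heavy atoms (6 carbon, 3 nitrogen; one five-membered aromatic ring with 3 hetero atoms, one six-membered aromatic ring with 1 hetero atom), on a carbonyl carbon

Among the measured compounds shown here, no measured pair isolates this exchange, so the expectation rests on where compound 3 stands and on the range that compounds 1 and 2 span. The step is expected to run downward, beyond the scatter, since compound 3 already sits near the top of what this assay can report; the expected step is a number 36 percentage points lower from compound 3 to compound 4 (beyond the scatter). Compound 4 is therefore estimated to give 60% in this assay, within a range from 30% to 90%.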

Compound 4, percent of the compound remaining: 68%
Compound 4: middle estimate off by 8 percentage points, on the low side; measured number inside the range.
By their numbers in this assay, from the lowest: compound 1; then compound 2; then compound 4; then compound 3.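

Among these compounds, the exchange on the carbonyl carbon whose other neighbours are an amide-type nitrogen gives the first step in this set that can be read at a single place: in this assay, the group of 9 heavy atoms with 2 nitrogen and 1 sulfur in place of the group of 9 heavy atoms with 3 nitrogen gives a number 28 percentage points lower from compound 3 to compound 4 (beyond the scatter). This position is therefore not indifferent to the group it carries, even though the two groups have the same counts of heavy atoms, hydrogen-bond donors and acceptors, the same ring sizes and no net charge, so these counts alone do not separate them. Nothing measured here accounts for the step.

From the compounds shown here alone, whether this exchange would move the number by a similar amount with the other sulfonyl parts seen in compound 1 and compound 2 remains open, as a single step cannot show how far it carries over. Also open, going by these compounds, is how a simpler group on the same carbonyl carbon, such as a single pyridine ring or a butyl chain, would compare with compound 3 and compound 4.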